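The source may report more compounds than this note shows. Statements on the series, on what has been measured and on what is new or still open speak of the compounds shown alone.

Compound 1 (`O=C1C=CC2(C=C1)OCC(=O)N2S(=O)(=O)c1ccccc1`) gives > 10000 nM in a functional assay on HepG2 cells (Homo sapiens) for inhibition, read by sulforhodamine B assay, with a stated time of 74 h (on this read-out lower numbers stand for stronger inhibition and higher numbers for weaker inhibition), and this value is a limit, not a number. Compound 2 (`N#Cc1cccc(S(=O)(=O)N2C(=O)COC23C=CC(=O)C=C3)c1`), which carries a cyano group in place of a hydrogen on the aromatic ring, gives > 10000 nM in this assay, and this too is a limit. Everything measured so far therefore comes down to the limit of > 10000 nM in this assay, at which 2 of the 2 values shown sit.

Compound 3 (`COc1ccc(S(=O)(=O)N2C(=O)COC23C=CC(=O)C=C3)cc1`) is reached from compound 1 by a single change, methoxy in place of hydrogen on an aromatic carbon, para to a large group. Among the compounds with values here, only one measured step bears on it, also a replacement of hydrogen on an aromatic carbon: a step that the two limits leave unreadable from compound 1 to compound 2. That step has no readable size, so it offers no direction and no magnitude for the methoxy change. Within the data shown here, with the limit of > 10000 nM in this assay, at which 2 of the 2 values shown sit, as the only guide, no step beyond the usual scatter is expected in this assay, and a further limit is the likeliest report. The expected step is a step that the limit leaves unreadable from compound 1 to compound 3. Compound 3 is estimated at 15000 nM, with an expected range from 6000 nM to 40000 nM.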

Compound 3, half-maximal inhibitory concentration: 1620 nM
For compound 3 the middle estimate is 9.3-fold (0.97 log units) above the measured one; the measured number lies below the stated range.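

Replacing a hydrogen of the aromatic ring with a methoxy group, para to a large group, gives an at least 6.1-fold lower number from compound 1 to compound 3 (0.79 log units; beyond the scatter) in this assay, and this is the only step shown with a readable direction. The step with cyano in place of hydrogen cannot be read, so a replacement on this aromatic ring now has a measured outcome for the first time, and compound 3 is the only compound shown that carries a number rather than a limit in this assay. Within the data shown here, the limit still accounts for most of the series, so a single methoxy group separates the one number from the rest only in the pair of compound 1 and compound 3: the limit of > 10000 nM in this assay, at which 2 of the 3 values shown sit.

The compounds shown leave open whether this step is particular to methoxy or would also appear with an ethoxy group, a hydroxyl group or a dimethylamino group at the same place, and whether methoxy on another carbon of the ring would give a step of similar size. As far as these compounds go, compound 1 carries only a limit, so the full size of the step also stays open.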